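Cinnamyl to Dimethylaminopropyl on a Purine Nucleoside Core

The source may report more compounds than this note shows. Statements on the series, on what has been measured and on what is new or still open speak of the compounds shown alone.

The series centres on a substituted purine nucleoside core, and the read-out of interest is a functional assay on the whole organism with Mus musculus as the target; a higher number here means a larger maximal response, a lower number a smaller maximal response. Compound 1 has the structure `Nc1nc(O)c2c(n1)n(C1OC(CO)[C@@H](O)[C@H]1O)c(=O)n2C/C=C/c1ccccc1`; in this assay compound 1 gives 5%, the lowest of the two numbers available. Its nearest neighbour is compound 2, `C=CCn1c(=O)n([C@H]2CO[C@@H](CO)C2)c2nc(N)nc(O)c21`, which in this assay gives 16%, a number that lies beyond the scatter of repeated measurements above compound 1. Among the measured compounds shown here, since compound 1 and compound 2 differ in more than one place, no single step between them can be drawn; their two values simply show that both sit at the low end of the scale.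

Compound 3, `CN(C)CCCn1c(=O)n(C2OC(CO)[C@@H](O)[C@H]2O)c2nc(N)nc(O)c21`, has not been measured. It differs from compound 1 by 2-(dimethylamino)ethyl in place of 2-phenylethenyl on a saturated chain carbon bound to an aromatic nitrogen. For the measured compounds named here, with no measured step that isolates this change, nothing in the data points to a direction for it, so the expected step from compound 1 to compound 3 is small, a number 7 percentage points higher from compound 1 to compound 3 (within the scatter), roughly within the scatter. Compound 3 is therefore estimated at 12%, with a range from 2% to 35%.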

Compound 3, largest response reached (reported as maximal response), in percent of the reference or control that the assay uses: 63%
Estimate against measurement, compound 3: 51 percentage points below; measured number outside the range, above it.
By their numbers in this assay, from the lowest: compound 1; then compound 2; then compound 3.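

At the saturated chain carbon bound to an aromatic nitrogen, 2-(dimethylamino)ethyl in place of 2-phenylethenyl gives a number 58 percentage points higher from compound 1 to compound 3 (beyond the scatter) in this assay. Among the compounds shown here, this is the first step that isolates a single place, and it shows that the low number of compound 1 is not set by the shared core alone: the group at this one position can move the maximal response far up the scale. The data do not say which part of the change carries the rise, whether the departure of the aromatic ring and double bond or the arrival of the nitrogen, and no independent measurement bears on it.

Still open, from the compounds shown here alone, is whether the nitrogen or the chain matters more, a question that a plain propyl chain, a longer aminoalkyl chain, a pyrrolidine or a morpholine at this place would separate. Also open, going by these compounds, is whether 3-(dimethylamino)propyl would bring a similar rise on the core of compound 2, in place of its prop-2-en-1-yl group.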